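Propargyl in Place of Phenyl on a Ring Nitrogen

This account rests on a few compounds, and the source may have more. Where it says the series, first, only, none or still open, it means among the compounds named here.

Of the compounds shown here, two have been measured in a functional assay on MGC-803 cells (Homo sapiens) for inhibition, read by MTT assay, with a stated time of 48 h, tested at 20 uM; on this read-out higher numbers stand for more inhibition at the one concentration tested (going by the name of the read-out) and lower numbers for less inhibition. Compound 1 `CCCn1c(SCc2ccc(C(C)(C)C)cc2)nc2c1c(=O)[nH]c(=O)n2C` gives 10.3%. Compound 2 `Cn1cnc2c1c(=O)n(CC(=O)N1CCN(c3ccccc3)CC1)c(=O)n2C` gives 4.6%, the lowest of the two numbers, yet its nearest neighbour, compound 1, lies within the scatter of it, so the two cannot be ranked against each other. Compound 3 `C#CCN1CCN(C(=O)Cn2c(=O)c3c(ncn3C)n(C)c2=O)CC1` has not been measured. It differs from compound 2 in one place: propargyl in place of phenyl on an amine nitrogen in a ring. Within the data shown here, no step between measured compounds that differ in one place is available, so nothing from the measured pair shows how such a change acts. Both measured numbers are small and within the scatter of each other, so compound 3 is expected to stay in the same low region, and the step of a number 2.4 percentage points higher from compound 2 to compound 3 (within the scatter) is expected to be none beyond the scatter. Compound 3 is therefore estimated at 7%, between 0% and 18%.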

Compound 3, a percentage reported as inhibition, at one concentration (the size of the read-out at that concentration, not a potency): 14.1%
Compound 3: middle estimate off by 7.1 percentage points, on the low side; the measured number falls inside the stated range.
By their numbers in this assay, from the lowest: compounds 2, 1 and 3 (each within the scatter of the next).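

Among these compounds, at the amine nitrogen in the ring, the change from phenyl to propargyl gives the first one-place step in this assay, a number 9.5 percentage points higher from compound 2 to compound 3 (within the scatter). The six-membered aromatic ring can therefore give way at this position to a group with no ring and a triple bond without the read-out moving beyond the scatter, so these two compounds do not show that the phenyl is needed for the low inhibition seen here. Nothing available explains this step or ties it to any property of either group. On these data alone, whether a benzyl, an acetyl or a simple methyl on the same nitrogen would shift the number beyond the scatter remains open. As far as these compounds go, it is also open whether a longer chain ending in an amine would do so.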